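Shortening the basic side chain of compound 1

This account rests on a few compounds, and the source may have more. Where it says the series, first, only, none or still open, it means among the compounds named here.

Compound 1 `CN1CCN(CCCCCCn2c3c(c4ccccc42)C(=O)c2c[n+]([O-])c4ccccc4c2C3=O)CC1` belongs to a set of three analogues sharing one core and differing only in the group attached to the aromatic nitrogen. In a functional assay on A-375 cells (Homo sapiens) for cytotoxicity, read by MTT assay, with a stated time of 72 h (on this read-out lower numbers stand for stronger inhibition and higher numbers for weaker inhibition), compound 1 gives 630 nM, the highest of the three numbers, though compound 2 `CC1(C)OCC(Cn2cc(Cn3c4c(c5ccccc53)C(=O)c3c[n+]([O-])c5ccccc5c3C4=O)nn2)O1` with 330 nM and compound 3 `O=C1c2c[n+]([O-])c3ccccc3c2C(=O)c2c1c1ccccc1n2Cc1cn([C@H]2O[C@H](CO)[C@@H](O)[C@H]2O)nn1` with 340 nM both lie within the scatter of it. For the measured compounds named here, the only measured step, a 1.0-fold higher number from compound 2 to compound 3 (0.01 log units; within the scatter), concerns a different part of the molecule and does not bear on the change that leads to compound 4 `CN(C)CCCCn1c2c(c3ccccc31)C(=O)c1c[n+]([O-])c3ccccc3c1C2=O`: dimethylamino in place of 2-(4-methylpiperazin-1-yl)ethyl on a saturated chain carbon, four bonds along the chain from an aromatic nitrogen. Going by the values given here, with no step touching this side chain, no shift beyond the scatter is expected, so compound 4 is estimated at 630 nM (range 250 nM to 1600 nM), a step of no change at the digits printed from compound 1 to compound 4 (within the scatter).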

Compound 4, half-maximal inhibitory concentration: 470 nM
Compound 4: the middle estimate sits 1.3-fold (0.13 log units) above what was measured, within the range that was stated.
By their numbers in this assay, from the lowest: compounds 2, 3, 4 and 1 (each within the scatter of the next).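

In this assay, putting dimethylamino in place of 2-(4-methylpiperazin-1-yl)ethyl gives a 1.3-fold lower number from compound 1 to compound 4 (0.13 log units; within the scatter) and so stays within the scatter. For the compounds shown here, this is the first measured step at this side chain, and it shows that the position tolerates losing the six-membered ring and most of the group's heavy atoms without a change beyond the scatter. Nothing measured here explains this result. The compounds shown leave open whether a primary amine, a morpholine or a carboxylic acid would fit at this place. They also leave open how a longer chain carrying dimethylamino would read.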